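Configuration step from compound 2 to compound 3

The compounds below may be only part of what the source reports. "The series", "measured", "known", "first", "only" and "open" are said of these compounds alone.

In a functional assay on P388 cells (Mus musculus) (a higher number here means that more compound is needed for the effect, a lower number that less compound is needed), compound 1 `Cc1nn(C[C@@H]2CO[C@H](CO)O2)c(=O)[nH]c1=O` gives > 100000 nM as a limit of the assay. Compound 2 `Cc1nn(C[C@H]2CO[C@H](CO)O2)c(=O)[nH]c1=O` gives > 100000 nM as a limit too, so its standing is not a readable number. The change to compound 3 `Cc1nn(C[C@H]2CO[C@@H](CO)O2)c(=O)[nH]c1=O` is the two compounds have the same atoms and bonds and differ only in configuration as drawn: 1 of 2 stereo elements differ; a stereocentre at a saturated ring carbon is drawn S in compound 2 and R in compound 3 with no atom or bond altered. Among the compounds with values here, the sole measured step of this kind is a step that the two limits leave unreadable from compound 1 to compound 2 with the fact that compounds 1 and 2 differ only in the configuration as drawn and the limit of > 100000 nM in this assay, at which 2 of the 2 values shown sit, as its setting, so it supplies no size to carry over. No step beyond the scatter is expected in this assay and a further limit is the likely report. The expected step is a number no higher from compound 2 to compound 3 (the limit leaves the size open) on that reading. For compound 3 the estimate is 100000 nM with 30000 nM to 300000 nM as the expected range.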

Compound 3, half-maximal effective concentration: > 100000 nM
Compound 3 ended at the assay's limit (the forecaster's own chance of this, stated with the estimate: 85%); the middle value sits exactly at the limit.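

In this assay, within the data shown here, compound 1, compound 2 and compound 3 all sit at the assay's limit, so no step among them can be read. The compounds shown leave open whether configuration changes the concentration needed in this assay at all.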